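A few compounds are considered here, and "the series" means these few. Any claim that something is new, unique, unknown or untested is made for them only; others in the source may bear on it.

- compound 1 `CCn1cc(C(CC)(CC)c2ccc(C#CC(O)(CC)CC)c(C)c2)cc1C(=O)NCC(=O)OC`: 26500 nM
- compound 2 `CCn1cc(C(CC)(CC)c2ccc(C#CC(O)(CC)CC)c(C)c2)cc1C(=O)OCCO`: 1880 nM

Both values come from a functional assay on MCF7 cells (Homo sapiens) for antiproliferative activity, read by MTT assay, with a stated time of 72 h (on this read-out higher numbers stand for weaker inhibition and lower numbers for stronger inhibition), and compound 2 holds the lower number of the two. Compound 3 `CCCCC(=O)c1cc(C(CC)(CC)c2ccc(C#CC(O)(CC)CC)c(C)c2)cn1CC` is not yet measured. It carries butyl in place of 2-hydroxyethoxy on a carbonyl carbon. Going by the values given here, the only measured step at this place is a 14-fold lower number from compound 1 to compound 2 (1.15 log units; beyond the scatter), a large one, so a change here may matter. That step involved a different pair of groups, so it says little about direction. A moderately higher number is expected, and the estimated step is a 2.1-fold higher number from compound 2 to compound 3 (0.33 log units; beyond the scatter). The estimate for compound 3 is 4000 nM, with an expected range of 800 nM to 20000 nM.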

Compound 3, half-maximal inhibitory concentration: > 50000 nM
Compound 3 gave a limit, no number; the forecaster's own chance of this, stated with the estimate: 10%; middle value at least 12-fold (1.09 log units) away from the limit.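

In this assay, putting butyl in place of 2-hydroxyethoxy on the carbonyl carbon gives an at least 26-fold higher number from compound 2 to compound 3 (1.42 log units; beyond the scatter), so the choice of group here can matter greatly even when both groups count 4 heavy atoms. Compound 3 gave a limit of the assay, not a number: the limit of > 50000 nM in this assay, at which 1 of the 3 values shown sits. The other comparison gives an at least 1.8-fold higher number from compound 1 to compound 3 (0.27 log units; that floor lies within the scatter), and with that floor within the scatter, it does not separate these two compounds.

Going by these compounds, it remains open whether the ester oxygen or the terminal hydroxyl of compound 2 matters more. On these data alone, how a 2-aminoethoxy group or a free carboxylic acid at this place would read also remains open.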